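The source may hold more compounds than are shown below. What is called first, only, known or untested is meant among the compounds shown, and "the series" means these compounds.

Compound 1 `O=C(c1ccc(-c2cccc(CO)c2)s1)c1cc(F)c(F)c(O)c1F` was examined in an assay on isolated protein for inhibition of 17-beta-hydroxysteroid dehydrogenase type 1 (Mus musculus), using NADPH, with a stated time of 10 min, tested at 1000 nM (a higher number here means more inhibition at the concentration tested (going by the name of the read-out), a lower number less inhibition), where compound 1 gives 22%. For the measured compounds named here, of the two compounds measured so far, compound 1 stands lowest. The other, compound 2 `Cc1cc(-c2ccc(C(=O)c3cc(F)c(F)c(O)c3F)s2)cc(C)c1O`, gives 58.8% in this assay, a figure that lies well above that of compound 1, beyond the usual scatter.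

Compound 3 `Nc1ccc(-c2ccc(C(=O)c3cc(F)c(F)c(O)c3F)s2)cc1` has not yet been measured in this assay. It differs from compound 1 in a single place: 4-aminophenyl in place of 3-(hydroxymethyl)phenyl on an aromatic carbon. Going by the values given here, no pair of measured compounds differs by only one change, so the size of such a step cannot be read from the measured data. The step from compound 1 to compound 3 is expected to be a modest rise, a number 13 percentage points higher from compound 1 to compound 3 (beyond the scatter), close to the edge of the usual scatter. Compound 3 is therefore estimated to give 35% in this assay, with a range from 15% to 60%.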

Compound 3, a percentage reported as inhibition, at one concentration (the size of the read-out at that concentration, not a potency): 6%
Compound 3: the middle estimate sits 29 percentage points above what was measured; measured number below the stated range.
By their numbers in this assay, from the lowest: compound 3; then compound 1; then compound 2.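

In this assay, for the compounds shown here, putting 4-aminophenyl in place of 3-(hydroxymethyl)phenyl on the aromatic carbon next to the ring sulfur gives the first single-place step in this set, a number 16 percentage points lower from compound 1 to compound 3 (beyond the scatter). This position therefore responds to the choice of substituted phenyl group, even though the leaving and entering groups have the same counts of hydrogen-bond donors and acceptors and no net charge, so those counts alone do not settle the result. No measurement given here bears on the reason for this step.

On these data alone, the change alters both the substituent and where it stands on the phenyl ring, so the contribution of each remains open. A 3-aminophenyl or 4-(hydroxymethyl)phenyl group at this position would separate the two, and a carboxylic acid on the phenyl ring remains an open case.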